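Replacing the amino group in a series stuck at its limit

A few compounds are considered here, and "the series" means these few. Any claim that something is new, unique, unknown or untested is made for them only; others in the source may bear on it.

- Compound 1 `C=C[C@@](C)(/C=C/c1ccc(Nc2ccc(OC)c(F)c2)cc1)CCC=C(C)C` reads > 43400 nM as a limit
- Compound 2 `C=C[C@@](C)(/C=C/c1ccc(Nc2ccc(F)c(F)c2)cc1)CCC=C(C)C` reads > 43400 nM as a limit
- Compound 3 `C=C[C@@](C)(/C=C/c1ccc(Nc2cc(F)c(F)c(F)c2)cc1)CCC=C(C)C` reads > 43400 nM as a limit

All three readings from a functional assay on NALM-6 cells (Homo sapiens) for cytotoxicity, with a stated time of 72 h (a lower number here means that less compound is needed, a higher number that more compound is needed for the effect), are limits and not numbers. Compound 2 therefore has no exact value and shares one reading with the other two compounds (the limit of > 43400 nM in this assay, at which 3 of the 3 values shown sit).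

In compound 4 `C=C[C@@](C)(/C=C/c1ccc(-c2ccc(Cl)cc2)cc1)CCC=C(C)C` a 4-chlorophenyl stands in place of (3,4-difluorophenyl)amino on an aromatic carbon (4-chlorophenyl in place of (3,4-difluorophenyl)amino on an aromatic carbon). Three measured steps exist in this series (a step that the two limits leave unreadable from compound 1 to compound 2; a step that the two limits leave unreadable from compound 2 to compound 3; a step that the two limits leave unreadable from compound 1 to compound 3). None has a readable size, and each only alters the substituents on the aryl group attached to the nitrogen, so none tests the removal of that nitrogen. They offer no measured size to carry over, and no clear step in this assay is expected. Compound 4 may well give a limit too. The estimated change is an at least 1.3-fold lower number from compound 2 to compound 4 (0.13 log units; that floor lies within the scatter), which is a modest expected move at best. For compound 4 the expected value is 32000 nM, with an estimated range from 10000 nM to 55000 nM.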

Compound 4, half-maximal effective concentration: > 43400 nM
Compound 4 gave a limit, no number (the forecaster's own chance of this, stated with the estimate: 65%); at least 1.3-fold (0.13 log units) between middle value and limit.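

In this assay compound 4 gives > 43400 nM, a limit and not a number. Within the data shown here, compound 2 also sits at a limit, so no step from compound 2 to compound 4 can be read, and all the compounds share one reading: the limit of > 43400 nM in this assay, at which 4 of the 4 values shown sit. From the compounds shown here alone, whether 4-chlorophenyl in place of (3,4-difluorophenyl)amino changes the effect at all remains open.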